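Swapping a carbon chain for an amino-bearing side chain

A few compounds are considered here, and "the series" means these few. Any claim that something is new, unique, unknown or untested is made for them only; others in the source may bear on it.

Compound 3 `CCc1nc(-c2ccc(Cl)cc2Cl)c(CC)nc1CC(CC)CC` gives 68 nM in an assay on IMR-32 cells for displacement of a labelled ligand from corticotropin-releasing factor receptor 1 (Homo sapiens), read by scintillation counting, with a stated time of 2 h (on this read-out lower numbers stand for stronger inhibition and higher numbers for weaker inhibition), the second highest of the three numbers recorded. Compound 1 `CCc1nc(-c2ccc(Cl)cc2Cl)c(CC)nc1NC(COC)COC` gives 224 nM, and compound 2 `CCc1nc(-c2ccc(Cl)cc2Cl)c(CC)nc1NC(C1CC1)C1CC1` gives 3.7 nM. Compound 4 `CCc1nc(-c2ccc(Cl)cc2Cl)c(CC)nc1NC(C)CN(C)C` has not yet been measured; it differs from compound 3 by (1-((dimethylamino)methyl)ethyl)amino in place of 2-ethylbutyl on an aromatic carbon, the entering group carrying 1 hydrogen-bond donor and 2 hydrogen-bond acceptors. Going by the values given here, two measured steps bear on this. The step of a 3.3-fold lower number from compound 1 to compound 3 (0.52 log units; beyond the scatter) shows that removing an acceptor-bearing amino substituent in favour of 2-ethylbutyl lowered the number modestly, while the step of an 18-fold higher number from compound 2 to compound 3 (1.26 log units; beyond the scatter) shows that the same 2-ethylbutyl gave a much higher number than the dicyclopropylmethylamino group. The group entering compound 4, acyclic and rich in heteroatoms, resembles that of compound 1 rather than compound 2, so a step back toward the region of compound 1 is expected, of size a 2.2-fold higher number from compound 3 to compound 4 (0.34 log units; beyond the scatter). Compound 4 is therefore estimated at 150 nM, within 40 nM to 600 nM.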

Compound 4, inhibition constant: 489 nM
Compound 4: the middle estimate sits 3.3-fold (0.51 log units) below what was measured, and the stated range covers the measured number.
By their numbers in this assay, from the lowest: compound 2; then compound 3; then compound 1; then compound 4.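

In this assay, the step of a 7.2-fold higher number from compound 3 to compound 4 (0.86 log units; beyond the scatter) shows that an amino link on this aromatic carbon does not by itself give a lower number than the 2-ethylbutyl carbon chain, since here (1-((dimethylamino)methyl)ethyl)amino gives the higher one. On the same ring nitrogen-bearing position, the change to 1-((dimethylamino)methyl)ethyl gives a 2.2-fold higher number from compound 1 to compound 4 (0.34 log units; beyond the scatter) and also a 130-fold higher number from compound 2 to compound 4 (2.12 log units; beyond the scatter) so that, of the side chains on that amino nitrogen, the one ending in dimethylamino stands furthest from dicyclopropylmethyl. No measurement shown here accounts for these differences.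

From the compounds shown here alone, it stays open whether the dimethylamino end or the branched chain carrying it sets the number of compound 4. A morpholine in place of the dimethylamino group, or a plain isopropyl on the nitrogen, would bear on that question.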